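Benzoyl in place of cyclohexylcarbonyl on the shared core

A few compounds are considered here, and "the series" means these few. Any claim that something is new, unique, unknown or untested is made for them only; others in the source may bear on it.

Of the compounds shown here, three sharing one core have been measured in an assay on isolated protein for inhibition of Nitric oxide synthase, inducible (Homo sapiens), read by scintillation counting, with a stated time of 30 min, tested at 50 uM; on this read-out lower numbers stand for less inhibition and higher numbers for more inhibition at the one concentration tested (going by the name of the read-out). Compound 3 `COc1ccc(N)c(C2=NN(C(=O)C3CCCCC3)C(C)(C)S2)c1` gives 100%, the highest of the three numbers. Compound 2 `CCCC(=O)N1N=C(c2cc(OC)ccc2N)SC1(C)C` gives 91.1%, and the step of a number 8.9 percentage points higher from compound 2 to compound 3 (within the scatter) lies within the scatter. Compound 1 `CC1(C)SC(c2ccccc2N)=NN1C(=O)c1ccccc1`, which lacks the methoxy group and carries a benzoyl group, gives 39.8%, a number beyond the scatter below that of compound 3.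

Compound 4 `COc1ccc(N)c(C2=NN(C(=O)c3ccccc3)C(C)(C)S2)c1` differs from compound 3 in one place: phenyl in place of cyclohexyl on a carbonyl carbon. Going by the values given here, no measured step follows this particular exchange. Among the compounds with values here, the one step available, a number 8.9 percentage points higher from compound 2 to compound 3 (within the scatter), shows that a change at the same carbonyl carbon left the number essentially unmoved. Compound 1 carries the same benzoyl group as compound 4 but differs from compound 3 in two places, so its lower value can only be read with caution.

On this basis compound 4 is expected to show 78%, in the range 45% to 100%, which would mean an estimated step of a number 22 percentage points lower from compound 3 to compound 4 (beyond the scatter).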

Compound 4, a percentage reported as inhibition, at one concentration (the size of the read-out at that concentration, not a potency): 0%
The estimate for compound 4 lay 78 percentage points above the measured number, and the stated range ends above it.
By their numbers in this assay, from the lowest: compound 4; then compound 1; then compounds 2 and 3 (each within the scatter of the next).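

At the carbonyl carbon, phenyl in place of cyclohexyl brings a number 100 percentage points lower from compound 3 to compound 4 (beyond the scatter) in this assay, and phenyl in place of propyl brings a number 91.1 percentage points lower from compound 2 to compound 4 (beyond the scatter) in the same read-out. This position, where propyl and cyclohexyl had given numbers within the scatter of each other, therefore separates both from phenyl, although phenyl differs from cyclohexyl only in being an aromatic ring of the same heavy-atom count. The earlier compounds shown here also offered no single-change view of the methoxy group, and with benzoyl held fixed, methoxy in place of hydrogen brings a number 39.8 percentage points lower from compound 1 to compound 4 (beyond the scatter) in this assay.

As far as these compounds go, it remains open whether the loss belongs to the phenyl ring itself or would persist with a pyridine ring or a benzyl group on the carbonyl carbon. From the compounds shown here alone, it is also open what the methoxy exchange does when propyl or cyclohexyl sits there, since it is seen here only with benzoyl. Nothing measured here accounts for these steps.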